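Aryl Swap on a Dibromo and Dichloro Phthalimide Core

The compounds below may be only part of what the source reports. "The series", "measured", "known", "first", "only" and "open" are said of these compounds alone.

Three phthalimide-type compounds have been examined in a functional assay on the whole organism (serum, strain Swiss albino) with Rattus norvegicus as the target, read by spectrophotometry, with a stated time of 14 days, at a dose of 10 mg/kg by the oral route (on this read-out lower numbers stand for less inhibition and higher numbers for more inhibition at the one dose given (going by the name of the read-out)), and a fourth awaits its number. Compound 1 `O=C1c2cc(Cl)c(Cl)cc2C(=O)N1c1ncccn1` gives 58% in this assay. Compound 2 `O=C1c2cc(Cl)c(Cl)cc2C(=O)N1c1ccncc1` gives 19% in this assay, and compound 3 `O=C1c2c(Br)c(Br)c(Br)c(Br)c2C(=O)N1c1ccncc1` gives 13% in this assay. The two values of compound 2 and compound 3 lie within the usual scatter of each other, so no order between them is claimed; compound 1 stands beyond the scatter above both of the others.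

For the measured compounds named here, the single change among the measured compounds is pyrimidin-2-yl in place of pyridin-4-yl on an amide-type nitrogen in a ring, and it produced the step of a number 39 percentage points higher from compound 2 to compound 1 (beyond the scatter), a large one. The cores of compound 2 and compound 3 differ in several places at once, and that difference is not broken down here.

The unmeasured compound 4 `O=C1c2c(Br)c(Br)c(Br)c(Br)c2C(=O)N1c1ncccn1` carries the same change on the core of compound 3: pyrimidin-2-yl in place of pyridin-4-yl on an amide-type nitrogen in a ring. The place is worded identically in both cases, so this is the same change made a second time. Compound 4 is therefore expected to give 45% in this assay, with a plausible range from 25% to 65%. That expectation rests on the step seen for compound 2 to compound 1, namely a number 39 percentage points higher from compound 2 to compound 1 (beyond the scatter), which makes the estimated step of a number 32 percentage points higher from compound 3 to compound 4 (beyond the scatter) for compound 4 a similar move, tempered somewhat since it is a single precedent on a different core.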

Compound 4, a percentage reported as inhibition, in the whole organism at one dose (the size of the read-out at that dose, not a potency): 19%
For compound 4 the middle estimate is 26 percentage points above the measured one; measured number below the stated range.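

In this assay the same change on the core of compound 3 gives a number 6 percentage points higher from compound 3 to compound 4 (within the scatter), which does not repeat the large step seen on the core of compound 1, and the two steps differ: the same change on two cores in this assay, a number 39 percentage points higher (beyond the scatter) from compound 2 to compound 1 and a number 6 percentage points higher (within the scatter) from compound 3 to compound 4, 33 percentage points apart, beyond the scatter of two such steps

This shows that, across these two pairs, the size of the step goes with the core that carries the change, so the step found on the chlorine-bearing core could not simply be carried over to the bromine-bearing one. It does not show which difference between the two cores matters, since they differ in several places at once, and two pairs give no rule for how the change would behave on any further core.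

The compounds shown carry only chlorine or bromine on the core, so it remains open how the same change would fare on a core with no halogen, or on one bearing fluorine, a methoxy group or an amine. On the ring nitrogen only pyridin-4-yl and pyrimidin-2-yl appear, which leaves open what a plain phenyl ring, a pyridin-2-yl group or a longer alkyl chain would give at this one dose.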